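The source may hold more compounds than are shown below. What is called first, only, known or untested is meant among the compounds shown, and "the series" means these compounds.

Working notes on the series built on the shared core of compound 1 `COc1ncnc2c1c(-c1cccs1)cn2[C@@H]1O[C@H](CO)[C@@H](O)[C@H]1O`. In an ADME assay on MRC5 cells (Homo sapiens), read by MTT assay, with a stated time of 72 h (a higher number here means a weaker inhibitor, a lower number a stronger inhibitor), compound 1 gives 43200 nM. Compound 2 `CNc1ncnc2c1c(-c1cccs1)cn2[C@@H]1O[C@H](CO)[C@@H](O)[C@H]1O` carries methylamino in place of methoxy on an aromatic carbon. In this assay compound 2 reaches only the limit of the assay, > 100000 nM, so no number exists for it. The step of an at least 2.3-fold higher number from compound 1 to compound 2 (0.36 log units; beyond the scatter) is therefore known only as a bound, resting on (the limit of > 100000 nM in this assay, at which 1 of the 2 values shown sits). Compound 3 `CN(C)c1ncnc2c1c(-c1cccs1)cn2[C@@H]1O[C@H](CO)[C@@H](O)[C@H]1O` differs from compound 2 by methyl in place of hydrogen on a nitrogen on an aromatic ring. Within the data shown here, no measured step concerns this change; the single measured step, an at least 2.3-fold higher number from compound 1 to compound 2 (0.36 log units; beyond the scatter), concerns a different exchange and sets only a bound. Compound 2 stands at the top of the numbers shown, so a shift beyond the scatter in either direction cannot be read from the data. Compound 3 is expected to stay near that upper edge, at 100000 nM (range 40000 nM to 300000 nM), the expected step being a number no higher from compound 2 to compound 3 (the limit leaves the size open), with a good chance that only a limit is reported again.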

Compound 3, half-maximal inhibitory concentration: > 100000 nM
Compound 3: only a limit was reported (the forecaster's own chance of this, stated with the estimate: 70%); the middle value lies on the limit itself.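

In this assay, dimethylamino in place of methoxy on an aromatic carbon gives an at least 2.3-fold higher number from compound 1 to compound 3 (0.36 log units; beyond the scatter), a bound of the same kind as an at least 2.3-fold higher number from compound 1 to compound 2 (0.36 log units; beyond the scatter). Both amine-bearing compounds therefore lie on the same side of compound 1, so this result extends the finding from methylamino to dimethylamino. The step from compound 2 to compound 3 cannot be read, because both compounds sit at the limit: the limit of > 100000 nM in this assay, at which 2 of the 3 values shown sit.

From the compounds shown here alone, whether the added methyl on the nitrogen changes the number at all remains open, and so does the full size of either exchange from methoxy. Among these compounds, also open is how other groups on this aromatic carbon, such as ethoxy, an unsubstituted amine or a morpholine ring, would compare with compound 1, the only compound here with a number rather than a limit.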